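This account rests on a few compounds, and the source may have more. Where it says the series, first, only, none or still open, it means among the compounds named here.

In an ADME assay on THP-1 cells (Homo sapiens) for cytotoxicity, read by trypan blue exclusion, with a stated time of 24 h (a lower number here means a stronger inhibitor, a higher number a weaker inhibitor), compound 1 (`N#C[Se]Cc1ccc([N+](=O)[O-])cc1`) gives 16800 nM. Compound 2 (`N#C[Se]Cc1cccc([N+](=O)[O-])c1`) gives 9320 nM, which lies within the scatter of compound 1. Compound 3 (`N#C[Se]Cc1ccccc1[N+](=O)[O-]`) gives 7100 nM, a lower number than compound 1 by more than the scatter, though it is within the scatter of compound 2. Compound 1 is therefore clearly set apart only from compound 3, and all three numbers fall in a narrow band. The three compounds differ only in where the nitro sits.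

The next compound, compound 4 (`N#C[Se]Cc1ccc(Br)cc1`), has not yet been measured. It keeps the core of compound 1 but carries bromo in place of nitro on an aromatic carbon. Going by the values given here, no measured pair in this set shows what such an exchange does, so the expectation rests only on the narrow band of the three measured numbers. A small step toward a lower number in this assay is expected, possibly no larger than the scatter. The estimated change is a 1.7-fold lower number from compound 1 to compound 4 (0.23 log units; within the scatter). For compound 4 the expected value is 10000 nM, with an estimated range of 5000 nM to 20000 nM.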

Compound 4, half-maximal inhibitory concentration: 28900 nM
The estimate for compound 4 lay 2.9-fold (0.46 log units) below the measured number, outside the stated range (above it).
By their numbers in this assay, from the lowest: compounds 3, 2, 1 and 4 (each within the scatter of the next, the first and the last beyond it).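

In this assay the exchange of nitro for bromo on this aromatic carbon, para to a group of 4 heavy atoms, gives a 1.7-fold higher number from compound 1 to compound 4 (0.24 log units; within the scatter) and so does not clearly separate the two compounds. Going by these compounds alone, this is the first measured step that changes the group itself rather than where the nitro sits, and it shows that compound 4, with bromo of 1 heavy atom and 0 hydrogen-bond acceptors in place of nitro with 3 heavy atoms and 2 hydrogen-bond acceptors, stays within the scatter of compound 1. The compounds shown offer no measurement that would account for this outcome.

On these data alone, whether bromo gives a similarly small step where compound 2 and compound 3 carry their nitro stays open, since this exchange can be read at only one place. Also open, as far as these compounds go, is what an amine, a carboxylic acid or a methoxy group would do on this aromatic carbon in this assay, and whether any of them would move the number beyond the scatter of compound 1.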